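This account rests on a few compounds, and the source may have more. Where it says the series, first, only, none or still open, it means among the compounds named here.

Measured so far:
compound 1, `O=C(CCc1ccccc1)NNc1c(Cl)cncc1Cl`, 650 nM in a functional assay on HEK293 cells for antagonist activity at P2X purinoceptor 7 (Homo sapiens), read by fluorescence, with a stated time of 2 h; on this read-out higher numbers stand for weaker inhibition and lower numbers for stronger inhibition
compound 2, `O=C(CCc1ccc(F)cc1)NNc1c(Cl)cncc1Cl`, 900 nM in this assay

Compound 1 has the smaller of the two numbers measured in this assay, but the gap to compound 2 lies within the scatter of repeated measurements, so the two cannot be told apart. Compound 3, `COc1ccc(CCC(=O)NNc2c(Cl)cncc2Cl)cc1`, has not yet been measured. It differs from compound 1 in one place: methoxy in place of hydrogen on an aromatic carbon. For the measured compounds named here, the only measured step that bears on this is a 1.4-fold higher number from compound 1 to compound 2 (0.14 log units; within the scatter), where a small group enters at the same kind of place on the same ring. Methoxy is a different group from fluoro, so this comparison is loose, but it is the only guide at hand. On that basis the step from compound 1 to compound 3 is expected to be small, either none beyond the scatter or a modest rise in the number. Compound 3 is therefore estimated at 900 nM, with a range from 400 nM to 2500 nM, which corresponds to an expected step of a 1.4-fold higher number from compound 1 to compound 3 (0.14 log units; within the scatter).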

Compound 3, half-maximal inhibitory concentration: 1500 nM
Estimate against measurement, compound 3: 1.7-fold (0.22 log units) below; the measured number falls inside the stated range.
By their numbers in this assay, from the lowest: compounds 1, 2 and 3 (each within the scatter of the next, the first and the last beyond it).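

In this assay, the aromatic carbon para to a large group now gives its first step beyond the scatter: methoxy in place of hydrogen brings a 2.3-fold higher number from compound 1 to compound 3 (0.36 log units; beyond the scatter) and so a modest loss of inhibition, which fluoro at this place did not show. The two groups themselves cannot be separated, as methoxy in place of fluoro gives a 1.7-fold higher number from compound 2 to compound 3 (0.22 log units; within the scatter) and leaves compound 2 and compound 3 indistinguishable in this read-out. No measurement at hand explains why methoxy shifts the number relative to hydrogen.

The compounds shown carry only hydrogen, fluoro or methoxy at this place, so it remains open whether an amine, a carboxylic acid or a longer chain such as ethoxy would raise the number further, leave it unchanged or lower it. Going by these compounds, it is also open whether methoxy would give a similar step on another carbon of the same ring, since all of the substituted compounds here carry their group at this one place.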